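This account rests on a few compounds, and the source may have more. Where it says the series, first, only, none or still open, it means among the compounds named here.

Of the compounds shown here, three sharing one core have so far been tested in an assay on CHO cells for displacement of a labelled ligand from adenosine receptor A1 (Homo sapiens), read by scintillation counting, with a stated time of 1 h, tested at 1 uM; a higher number here means more inhibition at the concentration tested (going by the name of the read-out), a lower number less inhibition. Compound 1 `Nc1ncc(-c2ccc(F)cc2)c(-c2ccccc2)n1` reaches the limit of this assay, giving > 80%. Compound 2 `COc1cccc(-c2cnc(N)nc2-c2ccccc2)c1` likewise sits at that limit, with > 80%. Compound 3 `COc1ccc(-c2cnc(N)nc2-c2ccccc2)cc1` is the only one of the three to return a number rather than a limit: in this assay compound 3 gives 56%. Going by the values given here, the single measured step between compounds differing in one place runs a number at least 24 percentage points lower from compound 1 to compound 3 (beyond the scatter), and because two of the three values sit at the limit of > 80% in this assay, at which 2 of the 3 values shown sit, its size is known only as a lower bound.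

Compound 4 `COc1ccc(-c2cnc(N)nc2-c2ccccc2)cc1OC` has not yet been measured. It differs from compound 3 by methoxy in place of hydrogen on an aromatic carbon. Among the compounds with values here, no measured step here adds a methoxy to a ring that already carries one, so no measured step bears directly on this change. Compound 2 shows that a molecule with one methoxy can sit at the limit. Compound 3 shows that one methoxy can also give a plain number. With no direct guide, the value of compound 4 is estimated at 45%, expected to lie between 20% and 75%. The expected step is therefore a number 11 percentage points lower from compound 3 to compound 4 (beyond the scatter), a small change in either direction not clearly beyond the scatter.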

Compound 4, a percentage reported as inhibition, at one concentration (the size of the read-out at that concentration, not a potency): > 80%
Compound 4 was reported as a limit; the forecaster's own chance of this, stated with the estimate: 10%; middle value at least 35 percentage points away from the limit.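

Adding a methoxy ortho to a methoxy group on the ring of compound 3 gives, in this assay, a number at least 24 percentage points higher from compound 3 to compound 4 (beyond the scatter). From the compounds shown here alone, compound 4 gives > 80%, which is a limit and not a number, so the true size of this step stays unknown beyond its lower bound. The same methoxy can also be seen as an addition to compound 2, but that step cannot be read, for this reason: the limit of > 80% in this assay, at which 3 of the 4 values shown sit.

Going by these compounds, how far compound 4 truly lies past its limit remains open, and so does any ranking among the compounds at that limit. It is also open whether the rise is specific to methoxy, since a hydroxyl, an amine or a longer chain such as ethoxy at this place is not among the compounds shown.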